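A few compounds are considered here, and "the series" means these few. Any claim that something is new, unique, unknown or untested is made for them only; others in the source may bear on it.

Measured so far:
compound 1, `O=C(O)[C@@H]1O[C@@H](OCCN2C(=O)CCC2=O)[C@@H](O)[C@@H](O)[C@@H]1O`, in an assay on isolated protein for binding affinity to fibroblast growth factor 2 (Homo sapiens), read by ELISA (a higher number here means a larger maximal response, a lower number a smaller maximal response), compound 1 gives 25%.
compound 2, `O=C(NC1OC(C(=O)O)C(O)C(O)C1O)c1ccncc1`, in this assay compound 2 gives 45%.

Compound 2 stands at the top of these two numbers. Its nearest neighbour is compound 1, whose value lies a long way lower, a gap that is beyond the usual scatter of repeated measurements. Among the compounds with values here, no pair of these two measured compounds differs in just one place, so no single structural step can be read from them; their two values simply show that compound 2 reaches the larger maximal response.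

The next compound is compound 3, `O=C(NC1OC(C(=O)O)C(O)C(O)C1O)c1cccs1`. It differs from compound 2 in one place: thiophen-2-yl in place of pyridin-4-yl on a carbonyl carbon. Within the data shown here, nothing measured here tells how such a change acts, since no step between measured compounds is available. The expectation is therefore that the step from compound 2 to compound 3 stays small, with no clear direction, a change of about a number 3 percentage points lower from compound 2 to compound 3 (within the scatter), which would not go beyond the scatter. On that basis compound 3 is estimated at 42% in this assay, with a range from 25% to 60%.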

Compound 3, largest response reached (reported as Imax), in percent of the reference or control that the assay uses: 40%
The estimate for compound 3 lay 2 percentage points above the measured number, within the range that was stated.
By their numbers in this assay, from the lowest: compound 1; then compounds 3 and 2 (each within the scatter of the next).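

In this assay, within the data shown here, thiophen-2-yl in place of pyridin-4-yl on a carbonyl carbon whose other neighbour is an amide-type nitrogen gives a number 5 percentage points lower from compound 2 to compound 3 (within the scatter), the first step that can be read at this position. It shows that, in this pair, exchanging a six-membered aromatic ring with a nitrogen for a five-membered aromatic ring with a sulfur leaves a difference in maximal response that cannot be told apart from the usual scatter, so the two groups cannot be ranked at this place. Nothing available here explains this outcome or says what either ring contributes to the response.

From the compounds shown here alone, whether the same holds for other groups on this carbonyl carbon remains open, for example a phenyl ring, a furan-2-yl ring, an amine-bearing ring or a longer alkyl chain, any of which might move the response beyond the scatter. Among these compounds, also open is how the amide link in compounds 2 and 3 compares with the chain of compound 1, since compound 1 differs from both in more than one place and no step to it can be read.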